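A few compounds are considered here, and "the series" means these few. Any claim that something is new, unique, unknown or untested is made for them only; others in the source may bear on it.

Measured so far in an ADME assay on BE(2)-C cells (Homo sapiens) for cytotoxicity, read by MTT assay, with a stated time of 20 h; a lower number here means that less compound is tolerated, a higher number that more compound is tolerated:

- compound 1 `CN1CCN(C(=O)C2CCN(C(=O)c3cc4ccccc4n3Cc3ccc(Cl)cc3)CC2)CC1` gives 75600 nM
- compound 2 `O=C(NCCn1ccnc1)C1CCN(C(=O)c2cc3ccccc3n2Cc2ccc(Cl)cc2)CC1` gives 99600 nM
- compound 3 `CN(Cc1ccccc1)C(=O)C1CCN(C(=O)c2cc3ccccc3n2Cc2ccc([N+](=O)[O-])cc2)CC1` gives > 100000 nM (a limit)

The entry for compound 3, > 100000 nM, is a limit of the assay and not a number. It is the one such entry here, as the limit of > 100000 nM in this assay, at which 1 of the 3 values shown sits, shows.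

Compound 4 `CN(Cc1ccccc1)C(=O)C1CCN(C(=O)c2cc3ccccc3n2Cc2ccncc2)CC1` differs from compound 3 in a single place, pyridin-4-yl in place of 4-nitrophenyl on a saturated chain carbon bound to an aromatic nitrogen.

Among the compounds with values here, no measured step touches this group. Within the data shown here, the only step with a number at both ends, a 1.3-fold higher number from compound 1 to compound 2 (0.12 log units; within the scatter), changes the group on a carbonyl carbon instead, so it bears on the new change only indirectly. It does show that a sizeable swap at that other place left the reading unmoved beyond the scatter.

With compound 1 at 75600 nM and compound 2 at 99600 nM, all the readings sit high, and no clear step in either direction is expected in this assay. For compound 4 the estimated value is 90000 nM, with an expected range from 50000 nM to 160000 nM. The expected step, an at least 1.1-fold lower number from compound 3 to compound 4 (0.04 log units; that floor lies within the scatter), is only a rough estimate, as it is set against a limit.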

Compound 4, half-maximal cytotoxic concentration: 80300 nM
Compound 4: middle estimate off by 1.1-fold (0.05 log units), on the high side, and the stated range covers the measured number.
By their numbers in this assay, from the lowest: compounds 1, 4 and 2 (each within the scatter of the next). At a limit, above all of these: compound 3.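

Within the data shown here, this is the first step that touches the group on the saturated chain carbon bound to an aromatic nitrogen, and in this assay the swap from 4-nitrophenyl to pyridin-4-yl gives an at least 1.2-fold lower number from compound 3 to compound 4 (0.09 log units; that floor lies within the scatter). Compound 3 gives > 100000 nM, which is a limit of the assay and not a number, so the step has only a floor, and the true size of the change cannot be read: the limit of > 100000 nM in this assay, at which 1 of the 4 values shown sits. Compound 4 gives 80300 nM, so this place now has one real number. The step alone cannot tell whether replacing a ring of carbon only with a ring holding a nitrogen moves the reading beyond the scatter.

Among these compounds, the 4-chlorophenyl group of compound 1 and compound 2 sits with different groups on the carbonyl carbon, so no one-place step sets it against 4-nitrophenyl or pyridin-4-yl. The compounds shown also leave open how this assay would read with a 4-aminophenyl group or a 4-carboxyphenyl group at this place, or with a longer chain in place of the single saturated carbon.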